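The source may hold more compounds than are shown below. What is called first, only, known or untested is meant among the compounds shown, and "the series" means these compounds.

Compounds with a measured value:
compound 1, `CC1=C(C(=O)OC2CCCC2)C(c2ccoc2)NC(=O)N1`, 6% 
compound 2, `CC1=C(C(=O)OC2CCCCC2)C(c2ccoc2)NC(=O)N1`, 15% 
compound 3, `CC1=C(C(=O)OC2CCCC2)C(c2cccs2)NC(=O)N1`, 9% 

All three were tested in an assay on membranes from CHO cells for displacement of a labelled ligand from adenosine receptor A1 (Homo sapiens), read by scintillation counting, with a stated time of 60 min, tested at 1 uM; a lower number here means less inhibition, a higher number more inhibition at the concentration tested (going by the name of the read-out). Compound 2 differs from compound 1 by cyclohexyl in place of cyclopentyl on an oxygen next to a carbonyl group, and this gave a number 9 percentage points higher from compound 1 to compound 2 (within the scatter). Compound 3 differs from compound 1 by thiophen-2-yl in place of furan-3-yl on a saturated ring carbon, with a number 3 percentage points higher from compound 1 to compound 3 (within the scatter). Compound 4, `CC1=C(C(=O)OC2CCCCC2)C(c2cccs2)NC(=O)N1`, has not been measured in this assay. It differs from compound 3 by cyclohexyl in place of cyclopentyl on an oxygen next to a carbonyl group, the same change that was made from compound 1 to compound 2. Because the earlier change gave a number 9 percentage points higher from compound 1 to compound 2 (within the scatter), a step of similar size is expected here, a number 7 percentage points higher from compound 3 to compound 4 (within the scatter). Compound 4 is therefore estimated to give 16% in this assay, between 4% and 30%.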

Compound 4, a percentage reported as inhibition, at one concentration (the size of the read-out at that concentration, not a potency): 7%
Beside the measured number, compound 4's estimate is 9 percentage points above it; the measured number falls inside the stated range.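

In this assay, cyclohexyl in place of cyclopentyl on the core of compound 3 gave a number 2 percentage points lower from compound 3 to compound 4 (within the scatter), and thiophen-2-yl in place of furan-3-yl on the core of compound 2 gave a number 8 percentage points lower from compound 2 to compound 4 (within the scatter). The cyclohexyl change cannot be told apart between the two cores: the same change on two cores in this assay, a number 9 percentage points higher (within the scatter) from compound 1 to compound 2 and a number 2 percentage points lower (within the scatter) from compound 3 to compound 4, 11 percentage points apart, within the scatter of two such steps. For the compounds shown here, the same holds for the thiophen-2-yl change, yet this does not show that either change carries over, only that no step or gap here stands clear of the scatter: the same change on two cores in this assay, a number 3 percentage points higher (within the scatter) from compound 1 to compound 3 and a number 8 percentage points lower (within the scatter) from compound 2 to compound 4, 11 percentage points apart, within the scatter of two such steps.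

The compounds shown leave open whether a longer chain on an oxygen next to a carbonyl group would give a step beyond the scatter. The same question remains for a phenyl ring or an amine on the saturated ring carbon.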